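Benzylamino in Place of Pentylselanyl on a Fused Core

The source may report more compounds than this note shows. Statements on the series, on what has been measured and on what is new or still open speak of the compounds shown alone.

Compound 1 `CCCCC[Se]c1nc(N)c2ccccc2n1`: 52300 nM
Compound 2 `[SeH]c1nc(NCc2ccccc2)c2cccnc2n1`: 8400 nM
Compound 3 `CCCCC[Se]c1nc([Se]CCCCC)c2ccccc2n1`: > 100000 nM

In an ADME assay on BEAS-2B cells (Homo sapiens) for cytotoxicity, read by MTT assay, with a stated time of 72 h (on this read-out lower numbers stand for stronger inhibition of growth and higher numbers for weaker inhibition of growth), compound 3 gives only a limit, > 100000 nM, and no number. That limit is the limit of > 100000 nM in this assay, at which 1 of the 3 values shown sits, so compound 3 has no number of its own among the values shown. Compound 4 `CCCCC[Se]c1nc(NCc2ccccc2)c2ccccc2n1` differs from compound 3 by a group of 8 heavy atoms (7 carbon, 1 nitrogen; one six-membered aromatic ring of carbon only) in place of a group of 6 heavy atoms (5 carbon, 1 selenium; no ring), on an aromatic carbon. For the measured compounds named here, the one measured step is an at least 1.9-fold higher number from compound 1 to compound 3 (0.28 log units; that floor lies within the scatter), which runs in the opposite direction and stays within the scatter. Compound 2 carries the same benzylamino group on a different core and gives 8400 nM, while compound 1 gives 52300 nM; neither pair has a counted step to compound 4. The step of an at least 3.3-fold lower number from compound 3 to compound 4 (0.52 log units; beyond the scatter) is therefore expected to bring the number down from the limit. Compound 4 is estimated at 30000 nM, within 8000 nM to 100000 nM.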

Compound 4, concentration for 50% growth inhibition: 44100 nM
For compound 4 the middle estimate is 1.5-fold (0.17 log units) below the measured one; low and high end bracket the measured number.
By their numbers in this assay, from the lowest: compound 2; then compounds 4 and 1 (each within the scatter of the next). At a limit, above all of these: compound 3.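

Benzylamino on this aromatic carbon, in place of the group of 6 heavy atoms, gives an at least 2.2-fold lower number from compound 3 to compound 4 (0.35 log units; beyond the scatter) in this assay. That step is only a floor, since compound 3 has a limit and no number: the limit of > 100000 nM in this assay, at which 1 of the 4 values shown sits. Adding benzyl to the nitrogen on this same carbon gives a 1.2-fold lower number from compound 1 to compound 4 (0.07 log units; within the scatter), so compound 1 and compound 4 do not separate.

The compounds shown leave open what a morpholine or a methylamino group would give on this carbon. They also leave open whether an ethylselanyl chain in place of pentylselanyl would alter the number.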